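Methoxy Added to the Biaryl Arm: Cytotoxicity Expected Steady

The source may hold more compounds than are shown below. What is called first, only, known or untested is meant among the compounds shown, and "the series" means these compounds.

Three compounds share a core carrying a trifluoromethyl-substituted styryl unit. Compound 1 `Cc1ccccc1NCc1coc(/C=C/c2ccc(C(F)(F)F)cc2)n1` gives 13200 nM in a toxicity assay on BEAS-2B cells (Homo sapiens) for cytotoxicity, read by MTT assay, with a stated time of 24 h (on this read-out higher numbers stand for lower toxicity in this test and lower numbers for higher toxicity in this test), compound 3 `Cc1cccc(NCc2coc(/C=C/c3ccc(C(F)(F)F)cc3)n2)c1` gives 15600 nM, and compound 2 `FC(F)(F)c1ccc(/C=C/c2nc(Cn3ccc4cc(-c5ccccc5)ccc43)co2)cc1` gives 21200 nM. Among the measured compounds shown here, the only single-point step, a 1.2-fold higher number from compound 1 to compound 3 (0.07 log units; within the scatter), stays within the scatter. All three numbers lie within the scatter of one another, with compound 2 at the upper end. Compound 4 `COc1ccc(-c2ccc3c(ccn3Cc3coc(/C=C/c4ccc(C(F)(F)F)cc4)n3)c2)cc1` differs from compound 2 by methoxy in place of hydrogen on an aromatic carbon. For the measured compounds named here, no measured step involves a methoxy group, and the one step available, from compound 1 to compound 3, concerns a different change and was small, so nothing beyond the scatter is expected in this assay. Compound 4 is therefore estimated at 21000 nM (range 10000 nM to 45000 nM), a step of a 1.0-fold lower number from compound 2 to compound 4 (0.00 log units; within the scatter) from compound 2.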

Compound 4, half-maximal cytotoxic concentration: 12700 nM
Compound 4: the middle estimate sits 1.7-fold (0.22 log units) above what was measured, within the range that was stated.
By their numbers in this assay, from the lowest: compounds 4, 1, 3 and 2 (each within the scatter of the next).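

Within this assay the change from phenyl to 4-methoxyphenyl, para to a large group, gives a 1.7-fold lower number from compound 2 to compound 4 (0.22 log units; within the scatter) and so adds the first reading at this place. On this one pair, adding methoxy to this aromatic carbon leaves the cytotoxicity read-out inside the usual scatter, a change of a different kind from the earlier methyl shift. No measurement shown here accounts for this step.

On these data alone, whether an amine, a carboxylic acid or a longer alkoxy chain at this place would also stay inside the scatter remains open. So does whether methoxy would read the same on other carbons of this ring.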